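Swapping a methoxy for an amino acid on the quinone ring

This account rests on a few compounds, and the source may have more. Where it says the series, first, only, none or still open, it means among the compounds named here.

Compound 1 `C=C1[C@H](C)CCC[C@]1(C)CC/C(C)=C/CC1=C(O)C(=O)C=C(N[C@@H](CO)C(=O)O)C1=O`, compound 2 `C=C1[C@H](C)CCC[C@]1(C)CC/C(C)=C/CC1=C(O)C(=O)C=C(OC)C1=O` and compound 3 `COC1=CC(=O)C(O)=C(C/C=C(\C)CC[C@@]2(C)CCC=C(C)[C@H]2C)C1=O` were all tested in an ADME assay on KB cells (Homo sapiens) for cytotoxicity, with a stated time of 48 h; a lower number here means a stronger inhibitor, a higher number a weaker inhibitor. For compound 1 the result is only a limit, > 10 ug/mL. For compound 2 the result is likewise a limit, > 10 ug/mL. For compound 3 too the assay gives only a limit, > 10 ug/mL, so all three sit at the same limit, as the limit of > 10 ug/mL in this assay, at which 3 of the 3 values shown sit, records. Within the data shown here, the single step on record, a step that the two limits leave unreadable from compound 1 to compound 2, cannot be sized. Compound 4 `CC1=CCC[C@](C)(CC/C(C)=C/CC2=C(O)C(=O)C=C(N[C@@H](C(=O)O)[C@@H](C)O)C2=O)[C@@H]1C` differs from compound 3 by (1-carboxy-2-hydroxypropyl)amino in place of methoxy on a double-bonded ring carbon. The reverse of this kind of change, from compound 1 to compound 2, showed nothing readable, so no shift beyond the scatter is expected: compound 4 is estimated at 15 ug/mL, within 7 ug/mL to 50 ug/mL, meaning an expected step that the limit leaves unreadable from compound 3 to compound 4.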

Compound 4, half-maximal inhibitory concentration: > 10 ug/mL
Compound 4: only a limit was reported; the forecaster's own chance of this, stated with the estimate: 85%; the middle value lies beyond the limit too.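

Among these compounds, the results for compound 3 and compound 4 are both limits rather than numbers, so no step between them can be read: the limit of > 10 ug/mL in this assay, at which 4 of the 4 values shown sit. The compounds shown leave open how strongly any of them acts in this assay, and whether (1-carboxy-2-hydroxypropyl)amino in place of methoxy changes that.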